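Compound 4: Removing a Methyl from Compound 3

This account rests on a few compounds, and the source may have more. Where it says the series, first, only, none or still open, it means among the compounds named here.

Measured so far in a functional assay on RXF 393 cells (Homo sapiens) for inhibition, read by sulforhodamine B assay, with a stated time of 48 h; a lower number here means a stronger inhibitor of growth, a higher number a weaker inhibitor of growth:
Compound 1 `COc1cc(C)cc(-c2c(-c3ccnc(-c4ccc(C(C)=O)cc4)c3)cnn2CC#N)c1` gives 2320 nM.
Compound 2 `Cc1cc(O)cc(-c2nn(CC#N)cc2-c2ccnc(-c3ccc(Oc4ccccc4)cc3)c2)c1` gives 2080 nM.
Compound 3 `COc1cc(C)cc(-c2nn(CC#N)cc2-c2ccnc(-c3ccc(N(C)C)cc3)c2)c1` gives 258 nM.

Compound 3 stands lowest of the three numbers; compound 2 and compound 1 both lie beyond the scatter above it. Compound 4 `Cc1cc(O)cc(-c2nn(CC#N)cc2-c2ccnc(-c3ccc(N(C)C)cc3)c2)c1` has not yet been measured in this assay. It differs from compound 3 in one place: hydrogen in place of methyl on an oxygen on an aromatic ring. Going by the values given here, compound 2 carries the same hydroxy group but a different group at the far end, so no measured pair isolates this change on its own. The step from compound 3 to compound 4 is expected to be a 1.4-fold higher number from compound 3 to compound 4 (0.13 log units; within the scatter), small and within the scatter. Compound 4 is therefore estimated at 350 nM, with a range from 150 nM to 900 nM.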

Compound 4, concentration for 50% growth inhibition: 2870 nM
Compound 4: the middle estimate sits 8.2-fold (0.91 log units) below what was measured; the measured number lies above the stated range.
By their numbers in this assay, from the lowest: compound 3; then compounds 2, 1 and 4 (each within the scatter of the next).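

In this assay, the methoxy group of compound 3 proves decisive: changing 3-methoxy-5-methylphenyl to 3-hydroxy-5-methylphenyl gives an 11-fold higher number from compound 3 to compound 4 (1.05 log units; beyond the scatter). With hydroxy in place, dimethylamino in place of phenoxy gives a 1.4-fold higher number from compound 2 to compound 4 (0.14 log units; within the scatter), so the two far-end groups are not told apart on this background. Nothing available accounts for the methoxy to hydroxy step. On these data alone, it remains open whether an ethoxy group or an amine in place of the methoxy would keep the number of compound 3. Also open, as far as these compounds go, is how phenoxy would read with the methoxy group present.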